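Swapping an ester for a thioamide on a thiophene core

This account rests on a few compounds, and the source may have more. Where it says the series, first, only, none or still open, it means among the compounds named here.

Three compounds built on the same core have been examined. Compound 1 `COC(=O)c1c(N)sc(-c2ccc(Cl)cc2)c1-c1ccc(Cl)cc1` carries a methoxycarbonyl group and, in a functional assay on PC-3 cells (Homo sapiens) for cytotoxicity, read by sulforhodamine B assay, with a stated time of 72 h (a higher number here means a weaker inhibitor, a lower number a stronger inhibitor), compound 1 gives 2780 nM. Compound 2 `Nc1sc(-c2ccc(Br)cc2)c(-c2ccc(Cl)cc2)c1C(=O)NC1CCCCC1` replaces that ester with a cyclohexyl amide and exchanges one chlorine for a bromine; in this assay compound 2 gives 28400 nM, which is the higher of the two numbers, so compound 1 stands as the stronger of the two measured entries. Compound 3 `Nc1sc(-c2ccc([N+](=O)[O-])cc2)c(-c2ccc(Cl)cc2)c1C(=O)NC1CC1` has a nitro group and a cyclopropyl amide, but for compound 3 this assay reports "not determined" (no result reported).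

Compound 4 `Nc1sc(-c2ccc(Cl)cc2)c(-c2ccc(Cl)cc2)c1C(=S)NC1CCCC1` is the next candidate. Going from compound 1 to compound 4, the change is a group of 8 heavy atoms (6 carbon, 1 nitrogen, 1 sulfur; one five-membered non-aromatic ring of carbon only) in place of a group of 4 heavy atoms (2 carbon, 2 oxygen; no ring), on an aromatic carbon. Within the data shown here, compound 2 is the only related comparison, and its larger secondary amide came with a much higher number than compound 1. A similar move upward is therefore expected, and the step from compound 1 to compound 4 is estimated at a 3.2-fold higher number from compound 1 to compound 4 (0.51 log units; beyond the scatter). In this assay compound 4 is expected to give about 9000 nM, most likely between 2500 nM and 35000 nM.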

Compound 4, half-maximal inhibitory concentration: 29000 nM
Beside the measured number, compound 4's estimate is 3.2-fold (0.51 log units) below it; the measured number falls inside the stated range.
By their numbers in this assay, from the lowest: compound 1; then compounds 2 and 4 (each within the scatter of the next).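

Compounds 1 and 4 differ in one place only, the aromatic carbon two ring bonds from the ring sulfur, so this pair shows the effect of this change alone, which compound 2, with its added bromine exchange, could not. In this assay, replacing the methoxycarbonyl group with the thioamide bearing a five-membered carbon ring gives a 10-fold higher number from compound 1 to compound 4 (1.02 log units; beyond the scatter), so at this position this larger group goes with clearly weaker cytotoxicity than the ester. No measurement shown here explains this loss.

The change brings in the thioamide sulfur and the carbon ring at once, so the compounds shown leave open which of them goes with the loss. An ordinary amide carrying the same five-membered carbon ring, or a carboxylic acid at this carbon, would help to separate these parts.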